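A second chloro on the pendant aryl ring

The source may report more compounds than this note shows. Statements on the series, on what has been measured and on what is new or still open speak of the compounds shown alone.

Measured so far in an ADME assay on isolated protein for inhibition of Amine oxidase [flavin-containing] B (Homo sapiens); on this read-out higher numbers stand for weaker inhibition and lower numbers for stronger inhibition:
compound 1 `C#CCNC1CCc2c(SCCc3ccc(Cl)cc3)cccc21`: 920 nM
compound 2 `C#CCNC1CCc2c(SCc3cccc(Cl)c3)cccc21`: 1090 nM
compound 3 `C#CCNC1CCc2c(SCc3cccc(Br)c3)cccc21`: a limit of the assay, > 100000 nM

Compound 1 shows the lowest of the two numbers, with compound 2 within the usual scatter of it. Compound 3 sits at a limit of the assay (the limit of > 100000 nM in this assay, at which 1 of the 3 values shown sits).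

Compound 4 `C#CCNC1CCc2c(SCCc3ccc(Cl)c(Cl)c3)cccc21` differs from compound 1 by chloro in place of hydrogen on an aromatic carbon. Within the data shown here, the only measured step, an at least 91-fold higher number from compound 2 to compound 3 (1.96 log units; beyond the scatter), concerns a halogen exchange rather than an added halogen, so it bears on this change only loosely. A small change is therefore expected, a 1.1-fold higher number from compound 1 to compound 4 (0.04 log units; within the scatter), not beyond the scatter. Compound 4 is estimated at 1000 nM, between 300 nM and 4000 nM.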

Compound 4, half-maximal inhibitory concentration: 2820 nM
Compound 4: the middle estimate sits 2.8-fold (0.45 log units) below what was measured; the measured number falls inside the stated range.
By their numbers in this assay, from the lowest: compounds 1 and 2 (each within the scatter of the next); then compound 4. At a limit, above all of these: compound 3.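

Placing a second chloro on the 4-chlorophenyl ring of compound 1, ortho to the existing chloro group, is not a neutral change in this assay but gives a 3.1-fold higher number from compound 1 to compound 4 (0.49 log units; beyond the scatter) and so weaker inhibition. Among these compounds, this is the first reading of a halogen added to this ring rather than exchanged for another. Nothing measured here explains the loss.

From the compounds shown here alone, whether it belongs to chloro itself or would follow any added group stays open. A fluoro, a methyl or a methoxy at this place is not among the compounds shown.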